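A few compounds are considered here, and "the series" means these few. Any claim that something is new, unique, unknown or untested is made for them only; others in the source may bear on it.

Compound 1 `CN[C@@H](C)C(=O)N[C@@H](CSCCS(=O)(=O)CCSC[C@H](NC(=O)[C@H](C)NC)C(=O)N1CCC[C@H]1C(=O)NC(c1ccccc1)c1ccccc1)C(=O)N1CCC[C@H]1C(=O)NC(c1ccccc1)c1ccccc1`: 52400 nM
Compound 2 `CN[C@@H](C)C(=O)N[C@@H](CSSC(C)(C)C)C(=O)N1CCC[C@H]1C(=O)NC(c1ccccc1)c1ccccc1`: 49900 nM

In a functional assay on MDA-MB-231 cells (Homo sapiens) for inhibition, with a stated time of 48 h (a lower number here means that less compound is needed, a higher number that more compound is needed for the effect), compound 2 gives 49900 nM, within the usual scatter of compound 1 at 52400 nM, so neither stands apart. Compound 3 `CN[C@@H](C)C(=O)N[C@@H](CO)C(=O)N1CCC[C@H]1C(=O)NC(c1ccccc1)c1ccccc1` differs from compound 2 by one change: hydroxy in place of ((tert-butyl)sulfanyl)sulfanyl on a saturated chain carbon, two bonds along the chain from an amide-type nitrogen and a carbonyl carbon. It carries hydroxy in place of ((tert-butyl)sulfanyl)sulfanyl on a saturated chain carbon. Going by the values given here, no measured pair of compounds shows what such a change does, so no step beyond the scatter is expected, in either direction. The expected change is a 1.2-fold lower number from compound 2 to compound 3 (0.10 log units; within the scatter). The estimated value for compound 3 is 40000 nM, with an expected range of 12000 nM to 100000 nM.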

Compound 3, half-maximal effective concentration: > 100000 nM
Compound 3: only a limit was reported (the forecaster's own chance of this, stated with the estimate: 25%); at least 2.5-fold (0.39 log units) between middle value and limit.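

In this assay, compound 3 is reported only as a limit of the assay, not as a number: the limit of > 100000 nM in this assay, at which 1 of the 3 values shown sits. Hydroxy in place of ((tert-butyl)sulfanyl)sulfanyl gives an at least 2.0-fold higher number from compound 2 to compound 3 (0.30 log units; that floor lies within the scatter), the first step seen at this position, though its true size is unknown and its floor alone does not clear the scatter. Even so, this change gives no sign of a lower number.

On these data alone, whether an amine, a carboxylic acid or a longer chain on this saturated chain carbon would lower the number remains open.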